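A few compounds are considered here, and "the series" means these few. Any claim that something is new, unique, unknown or untested is made for them only; others in the source may bear on it.

Three compounds share a core and differ only in the amino group attached to it. Compound 1 `CCCN(C)c1nc(C)nc2c(-c3c(C)cc(OC)cc3OC)c(C)nn12` carries a methyl(propyl)amino group and gives 6.48 nM in an assay on cell membranes for displacement of a labelled ligand from corticotropin-releasing factor receptor 1 (Rattus norvegicus); on this read-out lower numbers stand for stronger inhibition and higher numbers for weaker inhibition. Compound 2 `CCN(CCC#N)c1nc(C)nc2c(-c3c(C)cc(OC)cc3OC)c(C)nn12` carries a (2-cyanoethyl)(ethyl)amino group, and in this assay compound 2 gives 2.48 nM. Compound 3 `CCCN(CCC)c1nc(C)nc2c(-c3c(C)cc(OC)cc3OC)c(C)nn12` carries a dipropylamino group, and in this assay compound 3 gives 3.72 nM. Of the three numbers, compound 3 sits close to both neighbours: a 1.5-fold higher number from compound 2 to compound 3 (0.18 log units; within the scatter), and a 1.7-fold lower number from compound 1 to compound 3 (0.24 log units; within the scatter). Within the data shown here, the only step that reaches beyond the scatter is a 2.6-fold lower number from compound 1 to compound 2 (0.42 log units; beyond the scatter), which is modest.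

Compound 4 `C=CCN(CC=C)c1nc(C)nc2c(-c3c(C)cc(OC)cc3OC)c(C)nn12` is the next case. It differs from compound 3 by diallylamino in place of dipropylamino on an aromatic carbon. The change keeps the count of heavy atoms and the single hydrogen-bond acceptor and introduces two double bonds outside aromatic rings. Among the measured steps, the ones that bear on it are the swaps of one amino group for another of similar size, a 1.5-fold higher number from compound 2 to compound 3 (0.18 log units; within the scatter) and a 1.7-fold lower number from compound 1 to compound 3 (0.24 log units; within the scatter), both within the scatter. On that basis compound 4 is expected to show a 1.1-fold higher number from compound 3 to compound 4 (0.03 log units; within the scatter), that is, no shift beyond the scatter in this assay. The estimate for compound 4 is 4 nM, within a range from 1.5 nM to 11 nM.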

Compound 4, half-maximal inhibitory concentration: 1 nM
Estimate against measurement, compound 4: 4.0-fold (0.60 log units) above; the whole stated range lies above it.
By their numbers in this assay, from the lowest: compound 4; then compounds 2, 3 and 1 (each within the scatter of the next, the first and the last beyond it).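

Exchanging dipropylamino for diallylamino keeps the count of heavy atoms and adds two double bonds outside aromatic rings, and in this assay this exchange gives a 3.7-fold lower number from compound 3 to compound 4 (0.57 log units; beyond the scatter) and shows that the amino group on this aromatic carbon, between two ring nitrogen atoms, can shift the number beyond the scatter with no change in that count. Among these compounds, the earlier compounds showed only one step of that kind, and diallylamino now also gives a 2.5-fold lower number from compound 2 to compound 4 (0.39 log units; beyond the scatter) and a 6.5-fold lower number from compound 1 to compound 4 (0.81 log units; beyond the scatter) as well. With all three of its steps beyond the scatter, compound 4 is the most potent of the four compounds, and the step from methyl(propyl)amino is the largest shown here. Nothing measured here accounts for these shifts.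

The compounds shown leave open whether both allyl groups are needed, which an amino group carrying one allyl and one propyl chain would test, and whether the double bonds themselves matter, which a dipropargylamino group with its triple bonds or a bis(cyclopropylmethyl)amino group would help to separate. They also leave open whether diallylamino gives a similar step on a different core.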